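This account rests on a few compounds, and the source may have more. Where it says the series, first, only, none or still open, it means among the compounds named here.

In a functional assay on MGC-803 cells (Homo sapiens) for inhibition, read by MTT assay, with a stated time of 72 h (on this read-out higher numbers stand for weaker inhibition and lower numbers for stronger inhibition), compound 1 (`O=C(Nc1ccccc1)C1CCN(C/C=C/c2ccccc2)CC1`) gives 57900 nM and compound 2 (`COc1ccccc1NC(=O)C1CCN(C/C=C/c2ccccc2)CC1`) gives 71200 nM while compound 3 (`O=C(Nc1ccc(F)c(Br)c1)C1CCN(C/C=C/c2ccccc2)CC1`) gives 9270 nM and stands lowest of the three. Compound 4 (`O=C(Nc1nccs1)C1CCN(C/C=C/c2ccccc2)CC1`) has 1,3-thiazol-2-yl in place of 3-bromo-4-fluorophenyl on an amide-type nitrogen and so gives up the group that separates compound 3 from the others. Going by the values given here, two measured steps bear on this: a 6.2-fold lower number from compound 1 to compound 3 (0.80 log units; beyond the scatter) and a 7.7-fold lower number from compound 2 to compound 3 (0.89 log units; beyond the scatter). The step of a 1.2-fold higher number from compound 1 to compound 2 (0.09 log units; within the scatter) shows little response to the other change. Among the compounds with values here, no measured compound carries 1,3-thiazol-2-yl, so the transfer is uncertain, but a reversal of similar size is expected in this assay. The estimated step is a 4.3-fold higher number from compound 3 to compound 4 (0.63 log units; beyond the scatter) in this expectation. For compound 4 the estimate is 40000 nM with 13000 nM to 110000 nM as its expected range.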

Compound 4, half-maximal inhibitory concentration: 16400 nM
Estimate against measurement, compound 4: 2.4-fold (0.39 log units) above; low and high end bracket the measured number.
By their numbers in this assay, from the lowest: compounds 3 and 4 (each within the scatter of the next); then compounds 1 and 2 (each within the scatter of the next).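

Going by these compounds alone, at the amide-type nitrogen, 3-bromo-4-fluorophenyl is not the only group that separates from phenyl and 2-methoxyphenyl in this assay: the smaller, five-membered 1,3-thiazol-2-yl does so too (a 3.5-fold lower number from compound 1 to compound 4 (0.55 log units; beyond the scatter); a 4.3-fold lower number from compound 2 to compound 4 (0.64 log units; beyond the scatter)). Its difference from the halogenated ring stays within the scatter (a 1.8-fold higher number from compound 3 to compound 4 (0.25 log units; within the scatter)), so the lower numbers do not depend on a six-membered carbon ring or on halogen atoms. Nothing available explains this result.

The compounds shown leave open whether bromine or fluorine alone on the phenyl ring would suffice. They also leave open how a pyridin-2-yl group or an oxazol-2-yl group would behave at this nitrogen.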